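A few compounds are considered here, and "the series" means these few. Any claim that something is new, unique, unknown or untested is made for them only; others in the source may bear on it.

Measured compounds:
- compound 1 `CCCNS(=O)(=O)c1ccc(Nc2ncc3c(n2)N(C2CCCC2)[C@H](CC)C(=O)N3C)cc1`: 344 nM
- compound 2 `CCC1C(=O)N(C)c2cnc(-n3ccc4cc(C(N)=O)ccc43)nc2N1c1ccn(C)n1`: "not active" (no number reported)
- compound 3 `CCC1C(=O)N(C)c2cnc(Nc3ccc(S(=O)(=O)NC)cc3)nc2N1c1ccn(C)n1`: 3750 nM

In a functional assay on MCF7 cells (Homo sapiens) for antiproliferative activity, read by CCK-8 assay, with a stated time of 72 h (on this read-out lower numbers stand for stronger inhibition of growth and higher numbers for weaker inhibition of growth), compound 1 gives 344 nM, the lowest of the two numbers reported, while compound 3 gives 3750 nM, a gap that lies beyond the usual scatter. Compound 2 is reported as inactive, with no number given.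

Compound 4 `CC[C@@H]1C(=O)N(C)c2cnc(Nc3ccc(S(=O)(=O)NCC(C)C)cc3)nc2N1C1CCCC1` shares the core of compound 1 and differs from it only by methyl in place of hydrogen on a saturated chain carbon bound to two saturated chain carbons. The change is small and adds no ring, no hydrogen-bond donor and no acceptor, so the antiproliferative read-out is expected to shift little, in neither direction beyond the scatter. The expected step is a 1.1-fold lower number from compound 1 to compound 4 (0.03 log units; within the scatter). Compound 4 is therefore estimated at 320 nM, within a range of 130 nM to 900 nM.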

Compound 4, concentration for 50% growth inhibition: 403 nM
For compound 4 the middle estimate is 1.3-fold (0.10 log units) below the measured one; low and high end bracket the measured number.
By their numbers in this assay, from the lowest: compounds 1 and 4 (each within the scatter of the next); then compound 3.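

Within the data shown here, the first comparison here between compounds that differ in one place is a 1.2-fold higher number from compound 1 to compound 4 (0.07 log units; within the scatter) in this assay. Going from propylamino to isobutylamino, with a methyl added on a saturated chain carbon bound to two saturated chain carbons, therefore gives two compounds that this read-out cannot tell apart. No measurement shown here accounts for this result.

Among these compounds, a single added methyl is only one change at this place. Going by these compounds, whether a longer chain, a cyclohexyl ring or a terminal amine on this chain would also stay within the scatter remains open.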